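A few compounds are considered here, and "the series" means these few. Any claim that something is new, unique, unknown or untested is made for them only; others in the source may bear on it.

Measured compounds:
Compound 1 `COc1cc2c(Oc3ccc(NC(=O)N/N=C/c4ccc([N+](=O)[O-])cc4)cc3F)ccnc2cc1OCCCN1CCCC1`: 470 nM
Compound 2 `COc1cc2c(Oc3ccc(NC(=O)N/N=C/c4ccc(C(F)(F)F)cc4)cc3F)ccnc2cc1OCCCN1CCCC1`: 1300 nM
Compound 3 `COc1cc2c(Oc3ccc(NC(=O)N/N=C/c4ccc(F)cc4Cl)cc3F)ccnc2cc1OCCCN1CCCCC1`: 270 nM

In a functional assay on MKN-45 cells (Homo sapiens) for cytotoxicity, read by MTT assay, with a stated time of 72 h (a lower number here means a stronger inhibitor, a higher number a weaker inhibitor), compound 3 gives the lowest of the three numbers; compound 1 sits within the scatter of it, while compound 2 lies beyond. Compound 4 `COc1cc2c(Oc3ccc(NC(=O)N/N=C/c4ccc(OC(F)(F)F)cc4)cc3F)ccnc2cc1OCCCN1CCCCC1` differs from compound 3 in one place: 4-(trifluoromethoxy)phenyl in place of 2-chloro-4-fluorophenyl on a carbon with a double bond to nitrogen. Going by the values given here, no measured step swaps exactly this pair of groups. Among the compounds with values here, the only related step is a 2.8-fold higher number from compound 1 to compound 2 (0.44 log units; beyond the scatter), where a trifluoromethyl on the same ring weakened the compound modestly. The entering trifluoromethoxy resembles that trifluoromethyl in its fluorines, so a modest rise in the number is expected for compound 4, as a 2.6-fold higher number from compound 3 to compound 4 (0.41 log units; beyond the scatter). Compound 4 is therefore estimated at 700 nM, with a range from 250 nM to 2000 nM.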

Compound 4, half-maximal inhibitory concentration: 630 nM
Compound 4: middle estimate off by 1.1-fold (0.05 log units), on the high side; measured number inside the range.
By their numbers in this assay, from the lowest: compounds 3, 1 and 4 (each within the scatter of the next, the first and the last beyond it); then compound 2.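

In this assay, putting 4-(trifluoromethoxy)phenyl in place of 2-chloro-4-fluorophenyl on a carbon with a double bond to nitrogen gives a 2.3-fold higher number from compound 3 to compound 4 (0.37 log units; beyond the scatter). Going by these compounds alone, the earlier step at this place changed only one group on the ring, whereas this one replaces the whole ring with its groups, and the number still moves beyond the scatter. Nothing available explains this rise. Which part of the change matters stays open, since chlorine and fluorine leave together. An unsubstituted phenyl, or a phenyl carrying an amine or a carboxylic acid, also remains untested among these compounds.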